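This account rests on a few compounds, and the source may have more. Where it says the series, first, only, none or still open, it means among the compounds named here.

Measured in a functional assay on CCRF-CEM cells (Homo sapiens) for antiproliferative activity, read by cell counting, with a stated time of 72 h; a higher number here means a weaker inhibitor, a lower number a stronger inhibitor:
- compound 1 `C#C[C@@]1(O)[C@@H](CO)O[C@@H](n2cnc3c(-c4ccccc4)ncnc32)[C@@H]1O`: > 250000 nM
- compound 2 `C#C[C@@]1(O)[C@@H](CO)O[C@@H](n2cc(I)c3c(N)ncnc32)[C@@H]1O`: 120 nM

The entry for compound 1 is a limit of the assay and not a number.

Among the compounds with values here, compound 2, at 120 nM, carries the only actual number so far, so it has no numerical neighbour to be ranked against. The next compound to be read is compound 3 `C#Cc1cn([C@@H]2O[C@H](CO)[C@](O)(C#C)[C@H]2O)c2ncnc(N)c12`. It differs from compound 2 by one substituent: ethynyl in place of iodo on an aromatic carbon. In words, this is ethynyl in place of iodo on an aromatic carbon, with the rest of the structure unchanged.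

Within the data shown here, no step between measured compounds that differ in one place is available, so the expectation rests on this single change and on the value of compound 2. A moderate weakening in this assay is expected, possibly little beyond the scatter, and not a total loss of activity. The expected change is a 2.5-fold higher number from compound 2 to compound 3 (0.40 log units; beyond the scatter). For compound 3 the estimate is 300 nM, with an expected range from 60 nM to 2000 nM.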

Compound 3, half-maximal inhibitory concentration: 63000 nM
Estimate against measurement, compound 3: 210-fold (2.32 log units) below; measured number outside the range, above it.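

In this assay, within the data shown here, the aromatic carbon two ring bonds from the ring nitrogen proves highly sensitive to its substituent, as ethynyl in place of iodo gives a 530-fold higher number from compound 2 to compound 3 (2.72 log units; beyond the scatter) and is the first single change that can be read. Iodo and ethynyl are both free of rings, hydrogen-bond donors, hydrogen-bond acceptors and net charge, so none of these counted features separates the pair, yet this one exchange removes most of the activity of compound 2 on these cells. Compound 3 still carries a number and not a limit, so this step has a measured value at both ends and is not cut off by the limit of the read-out: the limit of > 250000 nM in this assay, at which 1 of the 3 values shown sits.

On these data alone, with only iodo and ethynyl at this position, it remains open whether the loss follows from the arrival of ethynyl or the departure of iodo, a question that bromo, chloro, methyl or a plain hydrogen at the same carbon would help to settle. Also open, as far as these compounds go, is how an amine or a longer chain at this carbon would read on these cells, and whether any group matches iodo here.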